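A few compounds are considered here, and "the series" means these few. Any claim that something is new, unique, unknown or untested is made for them only; others in the source may bear on it.

Three compounds have been measured in a functional assay on MDA-MB-231 cells (Homo sapiens) for cytotoxicity, read by sulforhodamine B assay, with a stated time of 72 h; a higher number here means a weaker inhibitor of growth, a lower number a stronger inhibitor of growth:

compound 1, `CCCC(=O)N1c2ccccc2CCC1C(=O)Nc1cc(C(F)(F)F)cc(C(F)(F)F)c1`, with compound 1 giving 15200 nM
compound 2, `O=C(Nc1ccccc1C(F)(F)F)C1CCc2ccccc2N1C(=O)c1ccc(Cl)cc1`, with compound 2 giving 533 nM
compound 3, `O=C(Nc1ccccc1O)C1CCc2ccccc2N1C(=O)c1ccccc1`, with compound 3 giving 4210 nM

Compound 1 stands at the highest number of the three, so it is the weakest inhibitor of growth among them in this assay. Compound 3 gives a lower number, and the gap lies beyond the scatter; compound 2 gives the lowest number of all, far beyond the scatter from compound 1. Both compound 2 and compound 3 carry an aromatic carbonyl group on the ring nitrogen of the shared core, whereas compound 1 carries a propylcarbonyl there.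

Compound 4, `O=C(Nc1cc(C(F)(F)F)cc(C(F)(F)F)c1)C1CCc2ccccc2N1`, has not been measured. It differs from compound 1 by hydrogen in place of propylcarbonyl on a nitrogen on an aromatic ring in a ring. Among the compounds with values here, no measured pair shows this change, so its effect is unknown from these data alone. With the acyl group removed entirely, a moderate shift in either direction seems possible, and compound 4 is expected to stay close to compound 1, a step of a 1.3-fold higher number from compound 1 to compound 4 (0.12 log units; within the scatter). Compound 4 is therefore estimated at 20000 nM, within a range from 6000 nM to 60000 nM.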

Compound 4, concentration for 50% growth inhibition: 8270 nM
Compound 4: the middle estimate sits 2.4-fold (0.38 log units) above what was measured, within the range that was stated.
By their numbers in this assay, from the lowest: compound 2; then compounds 3, 4 and 1 (each within the scatter of the next, the first and the last beyond it).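

In this assay, putting hydrogen in place of propylcarbonyl on the nitrogen of the shared core gives a 1.8-fold lower number from compound 1 to compound 4 (0.26 log units; within the scatter), so in this molecule the whole acyl group can go without the reading moving beyond the scatter. The earlier compounds shown here differ from one another in more than one place and could not isolate this position; this pair does, with the rest of the molecule unchanged. No measurement at hand bears on why the acyl group makes so little difference here.

On these data alone, how a longer chain, a methanesulfonyl group or a chain ending in a carboxylic acid on this nitrogen would read in this assay remains open. Also open, as far as these compounds go, is whether an aromatic carbonyl here would read differently from propylcarbonyl on this same molecule, as compound 2 and compound 3 differ from compound 1 in more than one place.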